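Removing the N-methyl from the isopropylsulfonamide in the series

The compounds below may be only part of what the source reports. "The series", "measured", "known", "first", "only" and "open" are said of these compounds alone.

Compound 1 `CC(C)S(=O)(=O)N(C)c1ccc(N(C)S(=O)(=O)c2ccc(F)cc2)cc1` is measured in a functional assay on the whole organism with Mus musculus as the target, with a stated time of 20 min (a lower number here means that less compound is needed, a higher number that more compound is needed for the effect), where compound 1 gives 1 mg/kg. Compound 2 `CC(C)S(=O)(=O)Nc1ccc(NC(=O)c2ccccc2)cc1` carries a hydrogen on both nitrogens and in this assay compound 2 gives 1 mg/kg, within the scatter of compound 1. Compound 3 `CC(C)S(=O)(=O)Nc1ccc(N(C)S(=O)(=O)c2ccc(F)cc2)cc1` differs from compound 1 by hydrogen in place of methyl on a sulfonamide nitrogen. Among the measured compounds shown here, no measured step covers this change, yet compound 2 at 1 mg/kg already shows that a hydrogen on this sulfonamide nitrogen sits with the same dose as compound 1; the expected step of no change at the digits printed from compound 1 to compound 3 (within the scatter) is therefore none beyond the scatter. Compound 3 is estimated at 1 mg/kg, with a range from 0.5 mg/kg to 3 mg/kg.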

Compound 3, minimum effective dose: 1 mg/kg
Compound 3: middle estimate and measured number agree at the digits printed, within the range that was stated.
By their numbers in this assay, from the lowest: compounds 1, 2 and 3 (each within the scatter of the next).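

Hydrogen in place of methyl on a sulfonamide nitrogen gives no change at the digits printed from compound 1 to compound 3 (within the scatter) in this assay. Among the compounds shown here, this is the first reading of that single change, as compound 2 differs from compound 1 in more than one place, and it shows that the methyl on this nitrogen is not required to stay within the scatter of the dose of compound 1. No supporting data bear on why this nitrogen tolerates the change.

Still open, going by these compounds, is whether a longer chain such as ethyl on this nitrogen would stay level. The same question applies to hydrogen in place of methyl on the other sulfonamide nitrogen of compound 3.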